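The compounds below may be only part of what the source reports. "The series", "measured", "known", "first", "only" and "open" are said of these compounds alone.

Working notes on the series.

Two cores are present. Compound 1 `O=C1CCCC2=C1C(c1ccccc1Cl)N=C(c1ccccn1)N2` and compound 2 `O=C1CCCC2=C1C(c1ccc(F)cc1)N=C(c1ccccn1)N2` share one core, compound 3 `CC1(C)CC(=O)C2=C(C1)NC(c1cccnc1)=NC2c1ccccc1Cl` and compound 4 `CC1(C)CC(=O)C2=C(C1)NC(c1cccnc1)=NC2c1ccc(F)cc1` share the other. The difference between the two cores is not broken down here.

In an ADME assay on HepG2 2.2.15 cells (Homo sapiens) for cytotoxicity (on this read-out higher numbers stand for weaker inhibition and lower numbers for stronger inhibition), compound 1 gives 589000 nM. In this assay compound 2 gives 516000 nM. The change from compound 1 to compound 2 is 4-fluorophenyl in place of 2-chlorophenyl on a saturated ring carbon and gives a 1.1-fold lower number from compound 1 to compound 2 (0.06 log units; within the scatter).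

In this assay compound 3 gives 67300 nM, which stands as the lowest of the three measured numbers, beyond the scatter from both compound 1 and compound 2.

Compound 4 is not yet measured. It differs from compound 3 by 4-fluorophenyl in place of 2-chlorophenyl on a saturated ring carbon. Within the data shown here, this is the same kind of change as the one from compound 1 to compound 2, but not the same: around the place, compound 3 carries a pyridin-3-yl group two ring bonds away, while compound 1 carries a pyridin-2-yl group there.

For compound 4 in this assay a step of about a 1.1-fold lower number from compound 3 to compound 4 (0.04 log units; within the scatter) is expected from compound 3, set beside the earlier step, because the same swap of groups produced only a 1.1-fold lower number from compound 1 to compound 2 (0.06 log units; within the scatter), which lies within the scatter. Whether the other core responds the same way is not shown by any measured pair here. On that basis compound 4 is estimated at 62000 nM, with a range from 25000 nM to 160000 nM.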

Compound 4, half-maximal inhibitory concentration: 145000 nM
Estimate against measurement, compound 4: 2.3-fold (0.37 log units) below; the measured number falls inside the stated range.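

In this assay, 4-fluorophenyl in place of 2-chlorophenyl on the saturated ring carbon gives a 2.2-fold higher number from compound 3 to compound 4 (0.33 log units; beyond the scatter), a modest step that lies beyond the scatter. Set beside the same change on the core of compound 1, this step cannot be told apart from the earlier one: the same change on two cores in this assay, a 1.1-fold lower number (0.06 log units; within the scatter) from compound 1 to compound 2 and a 2.2-fold higher number (0.33 log units; beyond the scatter) from compound 3 to compound 4, 2.5-fold (0.39 log units) apart, within the scatter of two such steps. Among these compounds, this shows that the two cores give no measurable disagreement on this change, but it does not show that the change carries over unaltered, as each core supplies only one pair and the earlier step on its own lies within the scatter.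

The compounds shown leave open which part of the difference between the two cores, if any, bears on the size of the step, and whether the halogen or the place it occupies on the phenyl ring matters, as this change alters both at once. They also leave open how either core would read in this cytotoxicity measurement with a phenyl group carrying an amine or a carboxylic acid in place of the halogen.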